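Aryl Swaps at the Saturated Ring Carbon

A few compounds are considered here, and "the series" means these few. Any claim that something is new, unique, unknown or untested is made for them only; others in the source may bear on it.

Three compounds sharing one core were examined in a functional assay on MCF7 cells (Homo sapiens) for cytotoxicity, read by MTT assay, with a stated time of 24 h; on this read-out lower numbers stand for stronger inhibition of growth and higher numbers for weaker inhibition of growth. Compound 1 `N#CC1=C(N)OC(c2c[nH]c3ccccc23)=C(C#N)C1c1ccc(Br)cc1` gives 48100 nM, compound 2 `COc1ccc(C2C(C#N)=C(N)OC(c3c[nH]c4ccccc34)=C2C#N)cc1OC` gives 37400 nM and compound 3 `N#CC1=C(N)OC(c2c[nH]c3ccccc23)=C(C#N)C1c1ccc(F)cc1` gives 52400 nM. Compound 3 stands as the highest of these three numbers, yet a 1.1-fold higher number from compound 1 to compound 3 (0.04 log units; within the scatter) and a 1.4-fold higher number from compound 2 to compound 3 (0.15 log units; within the scatter) both fall within the scatter. Compound 4 `N#CC1=C(N)OC(c2c[nH]c3ccccc23)=C(C#N)C1c1cccc2ccccc12` differs from compound 3 in one place: naphthalen-1-yl in place of 4-fluorophenyl on a saturated ring carbon. The steps bearing on this change are those exchanging the aryl group on the same saturated ring carbon, a 1.3-fold lower number from compound 1 to compound 2 (0.11 log units; within the scatter) and a 1.4-fold higher number from compound 2 to compound 3 (0.15 log units; within the scatter), neither of which exceeds the scatter. Going by the values given here, no measured step therefore supports expecting a shift beyond the scatter in this assay. Compound 4 is expected to give 45000 nM in this assay, with a range from 20000 nM to 100000 nM. The expected step is a 1.2-fold lower number from compound 3 to compound 4 (0.07 log units; within the scatter).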

Compound 4, concentration for total growth inhibition: 33900 nM
Estimate against measurement, compound 4: 1.3-fold (0.12 log units) above, within the range that was stated.
By their numbers in this assay, from the lowest: compounds 4, 2, 1 and 3 (each within the scatter of the next).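

In this assay the steps of a 1.5-fold lower number from compound 3 to compound 4 (0.19 log units; within the scatter) and a 1.1-fold lower number from compound 2 to compound 4 (0.04 log units; within the scatter) and a 1.4-fold lower number from compound 1 to compound 4 (0.15 log units; within the scatter) show that naphthalen-1-yl, with its second six-membered aromatic ring of carbon only, stays within the scatter of all three substituted phenyl groups on this saturated ring carbon. None of the four aryl groups shown therefore separates from the others at this position. Nothing available explains this result.

The compounds shown leave open whether an amine, a carboxylic acid or a longer chain on this carbon would separate from the aryl groups. They also leave open what replacing the 1H-indol-3-yl group would do.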